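The compounds below may be only part of what the source reports. "The series", "measured", "known", "first", "only" and "open" are said of these compounds alone.

Compound 1: `COc1cc2c(Oc3ccc(NC(=O)c4nnn(-c5ccccc5C)c4C)cc3F)ccnc2cc1OCCCN1CCCC1` gives 1600 nM.
Compound 2: `COc1cc2c(Oc3ccc(NC(=O)c4nnn(-c5ccccc5)c4C)cc3F)ccnc2cc1OCCCN1CCCC1` gives 1000 nM.

In a functional assay on U-87MG ATCC cells (Homo sapiens) for cytotoxicity, read by MTT assay, with a stated time of 72 h (a higher number here means a weaker inhibitor, a lower number a stronger inhibitor), compound 2 holds the lower of the two numbers shown, though the step of a 1.6-fold lower number from compound 1 to compound 2 (0.20 log units; within the scatter) lies within the scatter, so the two compounds cannot be told apart. Compound 3, `COc1cc2c(Oc3ccc(NC(=O)c4nnn(-c5ccccc5C(F)(F)F)c4C)cc3F)ccnc2cc1OCCCN1CCCC1`, differs from compound 2 by trifluoromethyl in place of hydrogen on an aromatic carbon. Among the measured compounds shown here, the only measured step that bears on this spot, a 1.6-fold lower number from compound 1 to compound 2 (0.20 log units; within the scatter), was within the scatter, which gives little ground to expect a large shift. Compound 3 is therefore expected to show a step of about a 1.3-fold higher number from compound 2 to compound 3 (0.11 log units; within the scatter), landing near 1300 nM, with a likely range from 500 nM to 3500 nM.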

Compound 3, half-maximal inhibitory concentration: 1060 nM
Compound 3: the middle estimate sits 1.2-fold (0.09 log units) above what was measured; low and high end bracket the measured number.
By their numbers in this assay, from the lowest: compounds 2, 3 and 1 (each within the scatter of the next).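

Going from phenyl to 2-(trifluoromethyl)phenyl in this assay gives a 1.1-fold higher number from compound 2 to compound 3 (0.03 log units; within the scatter), and trifluoromethyl in place of methyl on the same aromatic carbon gives a 1.5-fold lower number from compound 1 to compound 3 (0.18 log units; within the scatter). Hydrogen, methyl and trifluoromethyl at this spot therefore cannot be told apart in this assay, so the spot has now accepted a second, different group without a readable shift. No evidence is available to explain this result. From the compounds shown here alone, whether an amine or a carboxylic acid at this spot would move the number beyond the scatter remains open.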